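The source may hold more compounds than are shown below. What is called first, only, known or untested is meant among the compounds shown, and "the series" means these compounds.

Measured compounds: compound 1 `ClCc1ccc(Cn2cnc3nc(Cl)nc(Cl)c32)cc1`, compound 2 `ClCc1ccccc1Cn1cnc2ncnc(Cl)c21`, compound 3 `ClCc1ccccc1Cn1cnc2nc(Cl)nc(Cl)c21`.

In a functional assay on CAKI-1 cells (Homo sapiens) for cytotoxicity, read by sulforhodamine B assay, with a stated time of 48 h (a higher number here means a weaker inhibitor of growth, a lower number a stronger inhibitor of growth), compound 1 gives 2750 nM. Compound 2 gives 4160 nM in this assay, and compound 3 gives 34700 nM. Compound 3 and compound 2 differ in one place, (hydrogen in place of chloro on an aromatic carbon), and that change gave an 8.3-fold lower number from compound 3 to compound 2 (0.92 log units; beyond the scatter). Compound 1 and compound 3 are built from the same atoms joined differently; the difference between the two cores is not broken down here. Compound 4 `ClCc1ccc(Cn2cnc3ncnc(Cl)c32)cc1` has not been measured. It differs from compound 1 by hydrogen in place of chloro on an aromatic carbon, the same change that was seen from compound 3 to compound 2. Compound 4 is expected to show a 3.1-fold lower number from compound 1 to compound 4 (0.49 log units; beyond the scatter) in this assay, a step expected to run the same way but more cautiously sized because compound 1 already gives 2750 nM. Compound 4 is therefore estimated at 900 nM, with a range from 250 nM to 3000 nM.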

Compound 4, concentration for total growth inhibition: 4460 nM
Compound 4: middle estimate off by 5.0-fold (0.70 log units), on the low side; measured number above the stated range.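

On the core of compound 1, putting hydrogen in place of chloro gave a 1.6-fold higher number from compound 1 to compound 4 (0.21 log units; within the scatter), so this pair shows no real difference. The same swap clearly lowered the number on the other core, which shows that its effect does not carry reliably from one core to the other in this series: the same change on two cores in this assay, an 8.3-fold lower number (0.92 log units; beyond the scatter) from compound 3 to compound 2 and a 1.6-fold higher number (0.21 log units; within the scatter) from compound 1 to compound 4, 14-fold (1.13 log units) apart, beyond the scatter of two such steps. Going by these compounds alone, with only two pairs, this does not show why the cores differ or whether any other change would carry over.

The compounds shown leave open what an amine or a methoxy group would do in place of that chloro group on either core. They also leave open what would happen if the chloromethyl group were replaced by a hydroxymethyl group.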